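A methoxy-bearing five-membered ring replaces pyridin-3-yl

A few compounds are considered here, and "the series" means these few. Any claim that something is new, unique, unknown or untested is made for them only; others in the source may bear on it.

Measured in a functional assay on FaDu cells (Homo sapiens) for cytotoxicity, read by MTT assay, with a stated time of 72 h; a higher number here means that more compound is tolerated, a lower number that less compound is tolerated:
- Compound 1 `COc1ccc(NC(=O)C(=O)c2cn(C(C)C)c3ccccc23)nn1`: 2270 nM
- Compound 2 `COc1ccc(NC(=O)C(=O)c2cn(C(C)C)c3ccccc23)cn1`: 85 nM
- Compound 3 `CC(C)n1cc(C(=O)C(=O)Nc2cccnc2)c2ccccc21`: > 10000 nM (a limit of the assay)

Compound 3 stands at the limit of > 10000 nM in this assay, at which 1 of the 3 values shown sits. This is a limit, so compound 3 has no exact number.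

Compound 4 `COc1nc(NC(=O)C(=O)c2cn(C(C)C)c3ccccc23)ns1` differs from it on the amide-type nitrogen: a group of 7 heavy atoms (3 carbon, 2 nitrogen, 1 oxygen, 1 sulfur; one five-membered aromatic ring with 3 hetero atoms) in place of a group of 6 heavy atoms (5 carbon, 1 nitrogen; one six-membered aromatic ring with 1 hetero atom), on an amide-type nitrogen. Compound 1, compound 2 and compound 4 all carry a methoxy group, which compound 3 lacks.

Going by the values given here, three measured steps bear on this change. Hydrogen in place of methoxy gave an at least 110-fold higher number from compound 2 to compound 3 (2.07 log units; beyond the scatter), and pyridin-3-yl in place of 6-methoxypyridazin-3-yl gave an at least 4.4-fold higher number from compound 1 to compound 3 (0.64 log units; beyond the scatter). The ring that carries the methoxy also matters, since swapping it alone gave a 27-fold lower number from compound 1 to compound 2 (1.43 log units; beyond the scatter). Among the compounds with values here, no measured compound has a five-membered aromatic ring, so the size of the step remains uncertain.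

A move to a lower number in this assay is therefore expected, and the expected step is an at least 10-fold lower number from compound 3 to compound 4 (1.00 log units; beyond the scatter). Compound 4 is estimated at 1000 nM, within an expected range of 120 nM to 8000 nM.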

Compound 4, concentration lethal to 50% of the cells: > 10000 nM
Compound 4 was reported as a limit; the forecaster's own chance of this, stated with the estimate: 15%; at least 10-fold (1.00 log units) between middle value and limit.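

In this assay compound 4 gives > 10000 nM, which is a limit of the assay and not a number, so carrying a methoxy group does not by itself bring the number down. The ring that carries the methoxy counts at least as much, for the five-membered aromatic ring gave an at least 110-fold higher number from compound 2 to compound 4 (2.07 log units; beyond the scatter), and an at least 4.4-fold higher number from compound 1 to compound 4 (0.64 log units; beyond the scatter). The step between compound 3 and compound 4 cannot be read, since both values are limits: the limit of > 10000 nM in this assay, at which 2 of the 4 values shown sit.

The compounds shown leave open how far the true values of compound 3 and compound 4 lie past that limit, and whether another five-membered aromatic ring would fare differently. They also leave open whether an amine or an ethoxy chain in place of the methoxy of compound 2 would keep its low number.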